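Extending the alkoxy group of the lead compound 3

This account rests on a few compounds, and the source may have more. Where it says the series, first, only, none or still open, it means among the compounds named here.

Of the compounds shown here, three sharing one core have been measured in a functional assay on Jurkat cells (Homo sapiens) for activation, with a stated time of 24 h; a lower number here means that less compound is needed, a higher number that more compound is needed for the effect. Compound 1 `Oc1ccccc1CNc1ccc(-c2ccc(Cl)cc2)cc1` gives 2390 nM, compound 2 `Cc1ccc(-c2ccc(NCc3ccccc3O)cc2)cc1` gives 3790 nM, and compound 3 `COc1ccc(-c2ccc(NCc3ccccc3O)cc2)cc1` gives 580 nM, the lowest number of the three: the step of a 4.1-fold lower number from compound 1 to compound 3 (0.61 log units; beyond the scatter) and the step of a 6.5-fold lower number from compound 2 to compound 3 (0.82 log units; beyond the scatter) are both beyond the scatter, while a 1.6-fold higher number from compound 1 to compound 2 (0.20 log units; within the scatter) is not. Compound 4 `CC(C)Oc1ccc(-c2ccc(NCc3ccccc3O)cc2)cc1` carries the change (isopropyl in place of methyl on an oxygen on an aromatic ring). Among the compounds with values here, no measured step alters the group on that oxygen; the steps into compound 3 only show that the substituent at this position matters. With nothing directly comparable, the expected step of a 1.7-fold higher number from compound 3 to compound 4 (0.24 log units; within the scatter) for compound 4 is small and uncertain, and its estimate in this assay is 1000 nM, with a range from 300 nM to 3500 nM.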

Compound 4, half-maximal effective concentration: 5940 nM
Compound 4: middle estimate off by 5.9-fold (0.77 log units), on the low side, outside the stated range (above it).
By their numbers in this assay, from the lowest: compound 3; then compounds 1, 2 and 4 (each within the scatter of the next, the first and the last beyond it).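

In this assay, the group on the oxygen proves decisive: going from methoxy to isopropoxy gives (a 10-fold higher number from compound 3 to compound 4 (1.01 log units; beyond the scatter)), so the low number of compound 3 does not carry over to the isopropyl ether. Compound 4 is not separated from the methyl analogue (a 1.6-fold higher number from compound 2 to compound 4 (0.20 log units; within the scatter)), and it stands past the chloro analogue (a 2.5-fold higher number from compound 1 to compound 4 (0.40 log units; beyond the scatter)). Nothing available here accounts for this result. Going by these compounds, whether an ethyl group on that oxygen keeps the number of compound 3 remains open, as does the effect of an amine in place of the ether.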